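The source may report more compounds than this note shows. Statements on the series, on what has been measured and on what is new or still open speak of the compounds shown alone.

Compound 1 `COc1cc(-c2cc(COCc3cn(Cc4cc(-c5ccc(F)cc5)cnc4Cl)nn3)on2)cc(OC)c1OC` was examined in a functional assay on MCF7 cells (Homo sapiens) for cytotoxicity, read by MTT assay, with a stated time of 48 h (a lower number here means a stronger inhibitor, a higher number a weaker inhibitor), where compound 1 gives 76400 nM. Among the measured compounds shown here, this is the higher of the two numbers measured so far. For the measured compounds named here, the other measured compound, compound 2 `COc1cc(C2=NOC(COCc3cn(Cc4cc(-c5ccc(C)cc5)cnc4Cl)nn3)C2)cc(OC)c1OC`, differs from compound 1 in more than one place, and in this assay compound 2 gives 12900 nM, a clearly lower number; what the two values show is only that compound 1 is the weaker of the pair, and no single structural change can be read from them.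

Compound 3 `COc1cc(-c2cc(COCc3cn(Cc4cc(C)cnc4Cl)nn3)on2)cc(OC)c1OC` has not yet been measured in this assay. It differs from compound 1 in one place: methyl in place of 4-fluorophenyl on an aromatic carbon

Going by the values given here, no measured pair in this set carries the same change, so no step can be read off for it. The author therefore expects no step beyond the usual scatter, with the expected step of a 1.3-fold higher number from compound 1 to compound 3 (0.12 log units; within the scatter) pointing, if anywhere, towards a slightly higher number. Compound 3 is thus estimated at 100000 nM in this assay, with a range from 30000 nM to 350000 nM.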

Compound 3, half-maximal inhibitory concentration: 194000 nM
Compound 3: middle estimate off by 1.9-fold (0.29 log units), on the low side; measured number inside the range.
By their numbers in this assay, from the lowest: compound 2; then compound 1; then compound 3.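

Among the compounds shown here, compound 3 gives the first comparison in this set that differs in one place: replacing the 4-fluorophenyl group with methyl on the aromatic carbon para to the chloro group produces a 2.5-fold higher number from compound 1 to compound 3 (0.40 log units; beyond the scatter) in this assay, a modest step beyond the usual scatter. The position therefore registers this change, and the direction is towards a weaker inhibitor once the six-membered aromatic ring of carbon only is gone, with no hydrogen-bond donor or acceptor entering or leaving in the exchange. Nothing measured here accounts for the step.

This single pair cannot separate the loss of the aromatic ring from the loss of its fluorine, and it does not show how an unsubstituted phenyl, an amine or a longer alkyl chain would fare at this position. Going by these compounds, whether the same exchange would move the number in the same direction on the core of compound 2 also remains open, and a single step in one cell line says nothing about other cell types.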